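The source may hold more compounds than are shown below. What is called first, only, known or untested is meant among the compounds shown, and "the series" means these compounds.

Compound 1, `CCCNCCCOc1ccc2cc(NC(=O)c3ccc(O)c(CC=C(C)C)c3)c(=O)oc2c1C`, gives 990 nM in a functional assay on SK-BR-3 cells (Homo sapiens) for antiproliferative activity; a higher number here means a weaker inhibitor, a lower number a stronger inhibitor.
Compound 2, `CC(C)=CCc1cc(C(=O)Nc2cc3ccc(OCCCNCCO)c(C)c3oc2=O)ccc1O`, gives 610 nM in this assay.

For the measured compounds named here, compound 1 has the higher of the two numbers, but its only neighbour is compound 2, and a 1.6-fold lower number from compound 1 to compound 2 (0.21 log units; within the scatter) lies within the scatter, so nothing separates the two. Compound 3, `CC(C)=CCc1cc(C(=O)Nc2cc3ccc(OCCCNCc4ccccc4)c(C)c3oc2=O)ccc1O`, has not yet been measured. It differs from compound 1 by phenyl in place of ethyl on a saturated chain carbon bound to an amine nitrogen. Going by the values given here, the one measured step, from compound 1 to compound 2, alters the same chain, but there the change was hydroxy in place of methyl on a saturated chain carbon two bonds along the chain from an amine nitrogen, a change of a different kind, and it stayed within the scatter. Among the compounds with values here, no measured step bears directly on phenyl in place of ethyl, so the expectation in this assay is a step no larger than the scatter, in no settled direction. Compound 3 is expected to give about 800 nM, within 250 nM to 2500 nM. The expected step is a 1.2-fold lower number from compound 1 to compound 3 (0.09 log units; within the scatter).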

Compound 3, half-maximal inhibitory concentration: 470 nM
Beside the measured number, compound 3's estimate is 1.7-fold (0.23 log units) above it; the measured number falls inside the stated range.
By their numbers in this assay, from the lowest: compounds 3, 2 and 1 (each within the scatter of the next, the first and the last beyond it).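

For the compounds shown here, replacing propylamino with benzylamino gives the only step in this assay that lies beyond the scatter, a 2.1-fold lower number from compound 1 to compound 3 (0.32 log units; beyond the scatter), although it is a modest one. This shows that the group on the amine nitrogen can shift the number, and that one six-membered aromatic ring of carbon is tolerated there without a loss of activity. The comparison with the hydroxy-bearing chain, a 1.3-fold lower number from compound 2 to compound 3 (0.11 log units; within the scatter), separates nothing, and no available evidence accounts for either step.

The compounds shown leave open whether the ring has to be aromatic, a question that a cyclohexylmethyl group on the same nitrogen would address. They also leave open how a phenethyl group, or a benzyl ring carrying chlorine or methoxy, would compare with benzyl.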